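Hydrazone aryl swap at the assay limit

The compounds below may be only part of what the source reports. "The series", "measured", "known", "first", "only" and "open" are said of these compounds alone.

Measured so far in a functional assay on A549 cells (Homo sapiens) for antiproliferative activity, read by MTT assay; a higher number here means a weaker inhibitor, a lower number a stronger inhibitor:
- compound 1 `Cn1c(=O)c(=O)n(C2CCCC2)c2nc(N/N=C/c3ccc(O)cc3)ncc21` gives > 100000 nM as a limit
- compound 2 `COc1ccc(/C=N/Nc2ncc3c(n2)n(C2CCCC2)c(=O)c(=O)n3C)cc1` gives > 100000 nM as a limit

Compound 2 stands only at the limit > 100000 nM and has no readable number. The evidence is the limit of > 100000 nM in this assay, at which 2 of the 2 values shown sit, and shows no value away from it. Compound 3 `Cn1c(=O)c(=O)n(C2CCCC2)c2nc(N/N=C/c3ccccc3F)ncc21` has 2-fluorophenyl in place of 4-methoxyphenyl on a carbon with a double bond to nitrogen. Among the measured compounds shown here, the only measured step is a step that the two limits leave unreadable from compound 1 to compound 2 and it offers no size to carry over. Without a sized step, a large move in this assay is not expected, and a reading at the limit again is the likeliest outcome. The expected change is an at least 1.2-fold lower number from compound 2 to compound 3 (0.09 log units; that floor lies within the scatter) and this small move towards a stronger inhibitor is only an estimate. Compound 3 is estimated at 80000 nM with an expected range from 20000 nM to 100000 nM in this series.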

Compound 3, half-maximal inhibitory concentration: 31200 nM
Compound 3: middle estimate off by 2.6-fold (0.41 log units), on the high side; low and high end bracket the measured number.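

At this position, the carbon with a double bond to nitrogen, the aryl group can bring the series off the assay limit. In this assay, compound 3 gives 31200 nM, the first readable number. Placing 2-fluorophenyl in place of 4-methoxyphenyl gives an at least 3.2-fold lower number from compound 2 to compound 3 (0.50 log units; beyond the scatter), and placing it in place of 4-hydroxyphenyl gives an at least 3.2-fold lower number from compound 1 to compound 3 (0.50 log units; beyond the scatter). Both sizes are floors only, because the other end of each step is a limit and not a number: the limit of > 100000 nM in this assay, at which 2 of the 3 values shown sit.

The step between the two limit compounds cannot be read, so the hydroxy and methoxy groups remain unranked. Still open, going by these compounds, is whether the fluorine itself or its place on the ring carries the change, a question that 4-fluorophenyl, unsubstituted phenyl or 2-chlorophenyl on this carbon would help to separate.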